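Adding a Methyl to the Side Chain of Compound 1

The source may hold more compounds than are shown below. What is called first, only, known or untested is meant among the compounds shown, and "the series" means these compounds.

Measured compounds:
compound 1, `CC(C)[C@H](NC(=O)CN(c1nc(Cl)nc2[nH]cnc12)C1CC1)C(=O)OCc1ccccc1` — 55.5%
compound 2, `O=C(CN(c1ncnc2c1ncn2C1CCCCO1)C1CC1)N[C@@H](CCC(=O)OCc1ccccc1)C(=O)OCc1ccccc1` — 34.7%
compound 3, `NC(=O)C[C@H](NC(=O)CN(c1nc(Cl)nc2[nH]cnc12)C1CC1)C(=O)O` — 43.1%

Of the compounds shown here, three have been tested in a functional assay on the whole organism (Tail, strain ICR) with Mus musculus as the target, in the tail flick test, with a stated time of 60 min, at a dose of 25 umol/kg by the oral route; a lower number here means a weaker effect, a higher number a stronger effect of the compound at the dose given. Compound 1 stands highest of the three with 55.5%. The nearest to it is compound 3, whose 43.1% lies below by a margin beyond the scatter, and the furthest is compound 2, whose 34.7% lies lower still, also beyond the scatter. Among the compounds with values here, no pair among the measured compounds differs in a single place, so no directly comparable step is available.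

Compound 4, `CC[C@H](C)[C@H](NC(=O)CN(c1nc(Cl)nc2[nH]cnc12)C1CC1)C(=O)OCc1ccccc1`, is the next compound to be measured in this assay. It differs from compound 1 in one place: methyl in place of hydrogen on a saturated chain carbon, three bonds along the chain from an amide-type nitrogen and a carbonyl carbon. Within the data shown here, nothing among the measured compounds shows what such a change does, so the expectation rests on compound 1 alone, and the step is expected to be small, with no clear direction beyond the scatter, as a number 3.5 percentage points lower from compound 1 to compound 4 (within the scatter). Compound 4 is therefore estimated to give 52% in this assay, within a range from 35% to 68%.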

Compound 4, a percentage reported as activity, at one dose (the size of the read-out at that dose, not a potency): 40.6%
Compound 4: middle estimate off by 11.4 percentage points, on the high side; measured number inside the range.
By their numbers in this assay, from the lowest: compounds 2, 4 and 3 (each within the scatter of the next); then compound 1.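

In this assay, within the data shown here, the change from isopropyl to sec-butyl gives the first single-place comparison in this set, and a number 14.9 percentage points lower from compound 1 to compound 4 (beyond the scatter) shows that the step is not neutral. This saturated chain carbon, three bonds along the chain from an amide-type nitrogen and a carbonyl carbon, therefore responds to one added methyl, with the read-out falling by more than the usual scatter. No measurement at hand bears on why the number falls.

As far as these compounds go, whether a smaller side chain such as ethyl would raise the number, or a longer chain or a hydroxyl group at this place would lower it further, remains open. From the compounds shown here alone, it is equally open whether the same methyl step would hold with a carboxylic acid in place of the benzyl ester.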